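A few compounds are considered here, and "the series" means these few. Any claim that something is new, unique, unknown or untested is made for them only; others in the source may bear on it.

Compound 1 `O=C(/C=C\Nc1cnc2ccccc2c1)c1nc(-c2ccc(C(F)(F)F)cc2)n2ccccc12` — in a functional assay on MDA-MB-231 cells (Homo sapiens) for cytotoxicity, read by MTT assay, with a stated time of 48 h (a higher number here means a weaker inhibitor, a lower number a stronger inhibitor), compound 1 gives > 30000 nM, which is a limit of the assay and not a number.
Compound 2 `O=C(/C=C\Nc1cnc2ccccc2c1)c1nc(-c2ccccc2)n2ccccc12` — in this assay compound 2 gives 12300 nM.
Compound 3 `COc1ccc(N/C=C\C(=O)c2nc(-c3ccc(OC)cc3)n3ccccc23)cc1` — in this assay compound 3 gives > 30000 nM, again a limit of the assay rather than a number.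

Compound 1 therefore stands at the edge of what this assay can report; it is one of the two compounds sitting at the limit of > 30000 nM in this assay, at which 2 of the 3 values shown sit, and only compound 2 gives a number. The single step measured among these compounds is an at least 2.4-fold lower number from compound 1 to compound 2 (0.38 log units; beyond the scatter), and it concerns the trifluoromethyl group, which compound 4 keeps.

Compound 4 `COc1ccc(N/C=C\C(=O)c2nc(-c3ccc(C(F)(F)F)cc3)n3ccccc23)cc1OC` differs from compound 1 on the other side of the molecule: 3,4-dimethoxyphenyl in place of quinolin-3-yl on an amine nitrogen. No measured step changes the group on the amine nitrogen, so nothing among the shown compounds speaks directly to this change. Within the data shown here, compound 3, which carries a methoxyphenyl on the amine nitrogen and a methoxyphenyl in place of the trifluoromethylphenyl, also sits at the limit, but no step links it to compound 1 or compound 4.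

With compound 1 already at the limit, compound 4 is expected to show a step that the limit leaves unreadable from compound 1 to compound 4, that is, no step beyond the scatter, and most likely a limit again. For compound 4 the estimate in this assay is 40000 nM, with a range from 15000 nM to 100000 nM.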

Compound 4, half-maximal inhibitory concentration: > 30000 nM
Compound 4: a limit, no number; the forecaster's own chance of this, stated with the estimate: 75%; the middle value lies beyond the limit too.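

In this assay compound 4 gives > 30000 nM, which is a limit of the assay and not a number. Compound 1 also stands at a limit, so no step between compound 1 and compound 4 can be read: the limit of > 30000 nM in this assay, at which 3 of the 4 values shown sit.

The compounds shown leave open whether 3,4-dimethoxyphenyl in place of quinolin-3-yl on the amine nitrogen changes the value at all.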